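Swapping a methyl for a fluorine on the benzyl arm

The source may report more compounds than this note shows. Statements on the series, on what has been measured and on what is new or still open speak of the compounds shown alone.

Going by the values given here, compound 2 `C=CC1=C(C(=O)NCc2ccc(C)cc2)C(c2ccc(OC)cc2)OC1` is the only compound here with a real number in a functional assay on SW480 cells (Homo sapiens) for cytotoxicity, read by MTT assay, with a stated time of 24 h; a higher number here means a weaker inhibitor, a lower number a stronger inhibitor: in that assay compound 2 gives 31700 nM. Compound 1 `C=CC1=C(C(=O)NCc2ccc(Cl)cc2)C(c2ccc(OC)cc2)OC1` reached only a limit, as in this assay compound 1 gives > 100000 nM. That limit is the limit of > 100000 nM in this assay, at which 1 of the 2 values shown sits. Among the compounds with values here, the single measured step, an at least 3.1-fold lower number from compound 1 to compound 2 (0.49 log units; beyond the scatter), therefore shows that trading a chloro for a methyl on the aromatic ring of the benzyl arm made the inhibitor at least modestly stronger.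

Compound 3 `C=CC1=C(C(=O)NCc2ccccc2F)C(c2ccc(OC)cc2)OC1` changes the same arm again: 2-fluorophenyl in place of 4-methylphenyl on a saturated chain carbon bound to an amide-type nitrogen. This is the reverse direction of the measured step, from a methyl back to a halogen, though now fluorine rather than chloro and in the position named by the group. Because an at least 3.1-fold lower number from compound 1 to compound 2 (0.49 log units; beyond the scatter) points to a weaker inhibitor when a halogen sits on that ring, the expected step of a 1.9-fold higher number from compound 2 to compound 3 (0.28 log units; within the scatter) is a modest rise in the number, with a fair chance that only a limit is reported. Compound 3 is thus estimated at 60000 nM, with a range from 20000 nM to 200000 nM.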

Compound 3, half-maximal inhibitory concentration: > 100000 nM
Compound 3 was reported as a limit (the forecaster's own chance of this, stated with the estimate: 35%); middle value at least 1.6-fold (0.22 log units) from the limit.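

Replacing 4-methylphenyl with 2-fluorophenyl on the saturated chain carbon bound to the amide-type nitrogen gives an at least 3.1-fold higher number from compound 2 to compound 3 (0.49 log units; beyond the scatter), so the inhibitor becomes weaker and this arm again proves sensitive to change. Compound 1 and compound 3 carry different halogen-bearing rings, yet neither gives a real number in this assay, which means the loss seen with 4-chlorophenyl is no longer a single case among the compounds shown, while compound 2 remains the only one with a measured number. The step between compound 1 and compound 3 cannot be read, so these two halogen-bearing arms cannot be ranked, and all that can be said is that they share the same ceiling: the limit of > 100000 nM in this assay, at which 2 of the 3 values shown sit.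

Going from 4-methylphenyl to 2-fluorophenyl changes both the substituent and the name of its ring position at once, so 4-fluorophenyl and 2-methylphenyl arms would be needed to separate those two changes. As far as these compounds go, it also remains open how an unsubstituted phenyl or a 4-methoxyphenyl arm would behave in this assay.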